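Spiro sulfone series: acyl groups at the ring carbon

The compounds below may be only part of what the source reports. "The series", "measured", "known", "first", "only" and "open" are said of these compounds alone.

Compound 1 `O=S(=O)(c1ccc(Oc2ccc(OC(F)(F)F)cc2)cc1)C1CCC2(CCNCC2)C1` carries a hydrogen on the saturated ring carbon of the five-membered ring of its core. In a functional assay on blood (Homo sapiens), with a stated time of 60 min, in the presence of a further agent that is not named here (on this read-out higher numbers stand for an effect only at larger amounts of compound and lower numbers for an effect already at smaller amounts), compound 1 gives only a limit, > 15000 nM. Compound 2 `COC(=O)C1(S(=O)(=O)c2ccc(Oc3ccc(OC(F)(F)F)cc3)cc2)CCC2(CCNCC2)C1` bears methoxycarbonyl at that place, and in this assay compound 2 likewise gives only a limit, > 15000 nM. Compound 3 `NC(=O)C1(S(=O)(=O)c2ccc(Oc3ccc(OC(F)(F)F)cc3)cc2)CCC2(CCNCC2)C1` bears carbamoyl there, and in this assay compound 3 gives 3700 nM. Compound 1 thus sits at the limit shared by two of the three values (the limit of > 15000 nM in this assay, at which 2 of the 3 values shown sit); its standing against compound 2 cannot be read, as a step that the two limits leave unreadable from compound 1 to compound 2 shows, whereas an at least 4.0-fold lower number from compound 1 to compound 3 (0.60 log units; beyond the scatter) and an at least 4.0-fold lower number from compound 2 to compound 3 (0.60 log units; beyond the scatter) show a readable number for the carbamoyl compound.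

Compound 4 `O=C1CN(C(=O)C2(S(=O)(=O)c3ccc(Oc4ccc(OC(F)(F)F)cc4)cc3)CCC3(CCNCC3)C2)CCN1` differs from compound 1 by (3-oxopiperazin-1-yl)carbonyl in place of hydrogen on a saturated ring carbon. Of the measured steps, an at least 4.0-fold lower number from compound 1 to compound 3 (0.60 log units; beyond the scatter) bears most on this change, the carbamoyl and the entering group both being carbonyl-linked amides; a step that the two limits leave unreadable from compound 1 to compound 2 shows that a carbonyl alone need not bring a number. For compound 4 a lower number is expected, an at least 3.0-fold lower number from compound 1 to compound 4 (0.47 log units; beyond the scatter), though a limit remains possible. Compound 4 is expected at 5000 nM, within a range from 1500 nM to 16000 nM.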

Compound 4, half-maximal effective concentration: 7500 nM
Estimate against measurement, compound 4: 1.5-fold (0.18 log units) below; measured number inside the range.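

In this assay compound 4 shows that this ring carbon can carry (3-oxopiperazin-1-yl)carbonyl and still give a number rather than a limit, with an at least 2.0-fold lower number from compound 1 to compound 4 (0.30 log units; that floor lies within the scatter) and an at least 2.0-fold lower number from compound 2 to compound 4 (0.30 log units; that floor lies within the scatter) as the steps from the two limit compounds. Among the amides, 3-oxopiperazin-1-yl in place of amino on the carbonyl carbon gives a 2.0-fold higher number from compound 3 to compound 4 (0.31 log units; beyond the scatter), so the larger amide does not improve on carbamoyl. Compound 1 and compound 2 remain limits of the assay, not numbers: the limit of > 15000 nM in this assay, at which 2 of the 4 values shown sit.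

Still open, as far as these compounds go, is whether a carboxylic acid, a nitrile or a dimethylamide at this ring carbon would give a number at all. The steps from the two limit compounds give only floors, so the true distance of compound 4 from either stays unread.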